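The compounds below may be only part of what the source reports. "The series", "measured", "known", "first", "only" and "open" are said of these compounds alone.

Measured so far, in a functional assay on HeLa cells (Homo sapiens) for inhibition, read by CCK-8 assay, with a stated time of 48 h; a higher number here means a weaker inhibitor, a lower number a stronger inhibitor:
compound 1 `Fc1ccc(C2=NN(C3=NC(c4ccccc4)CS3)C(c3cccc4ccccc34)C2)cc1` gives 12400 nM
compound 2 `Fc1ccc(C2=NN(C3=NC(c4ccccc4)CS3)C(c3ccc4ccccc4c3)C2)cc1` gives 9730 nM

Compound 2 stands at the lower of the two numbers, but the step of a 1.3-fold lower number from compound 1 to compound 2 (0.11 log units; within the scatter) is within the scatter, so on these data compound 1 and compound 2 cannot be told apart. The next compound, compound 3 `Clc1ccc(C2=NN(C3=NC(c4ccccc4)CS3)C(c3ccc4ccccc4c3)C2)cc1`, differs from compound 2 by chloro in place of fluoro on an aromatic carbon. Among the compounds with values here, no measured step touches that spot: the single step known, a 1.3-fold lower number from compound 1 to compound 2 (0.11 log units; within the scatter), concerns the group on the saturated ring carbon and says nothing about the halogen on the six-membered aromatic ring of carbon only. Within the data shown here, with no comparable step to lean on, the expectation for compound 3 is a number close to that of compound 2, and the step of a 1.3-fold lower number from compound 2 to compound 3 (0.11 log units; within the scatter) is expected to stay within the scatter. Compound 3 is therefore estimated at 7500 nM in this assay, with a range from 3000 nM to 20000 nM.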

Compound 3, half-maximal inhibitory concentration: 7560 nM
For compound 3 the middle estimate is 1.0-fold (0.00 log units) below the measured one, within the range that was stated.
By their numbers in this assay, from the lowest: compounds 3, 2 and 1 (each within the scatter of the next).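

In this assay, within the data shown here, the halogen on the aromatic carbon, para to a large group, now has its first measured step, which the earlier compounds could not supply: a 1.3-fold lower number from compound 2 to compound 3 (0.11 log units; within the scatter). The change from 4-fluorophenyl to 4-chlorophenyl therefore gives no readable difference at this position, and on these data the identity of these two halogens cannot be separated in this assay. Nothing measured alongside the result bears on what lies behind this outcome.

The compounds shown cover only fluoro and chloro at this place, so a bromo, a methoxy, an amine or a carboxylic acid could still show whether any group here moves the number beyond the scatter, and the plain phenyl without a halogen would give a reference point for both halogens. From the compounds shown here alone, it also remains open whether the step seen here would hold with the naphthalen-1-yl group on the saturated ring carbon, or with a hydroxy or amine on the other phenyl group of the shared core.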